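A few compounds are considered here, and "the series" means these few. Any claim that something is new, unique, unknown or untested is made for them only; others in the source may bear on it.

Measured compounds:
compound 1 `COc1cc(C)cc(-c2c(-c3ccnc(-c4ccc(C(C)=O)cc4)c3)cnn2CC#N)c1` with 9%
compound 2 `COc1cc(C)cc(-c2nn(CC#N)cc2-c2ccc(-c3cccc(C(C)=O)c3)nc2)c1` with 4%
compound 3 `Cc1cc(O)cc(-c2nn(CC#N)cc2-c2ccnc(-c3ccc(Oc4ccccc4)cc3)c2)c1` with -39%

These three compounds were tested in a functional assay on KM12 cells (Homo sapiens) for cytotoxicity, read by sulforhodamine B assay, with a stated time of 48 h, tested at 1 uM; a higher number here means a weaker effect of the compound at the concentration tested, a lower number a stronger effect. Compound 1 gives the highest of the three numbers, at 9%. Compound 2, at 4%, sits within the usual scatter of compound 1, so the two cannot be told apart. Compound 3, at -39%, lies well beyond that scatter. No pair of these compounds differs in only one place, so no single step has been measured. Compound 4 `COc1cc(C)cc(-c2c(-c3ccnc(-c4ccc(N(C)C)cc4)c3)cnn2CC#N)c1` is compound 1 with one change: dimethylamino in place of acetyl on an aromatic carbon. Within the data shown here, with no measured step to lean on, the expected step in this assay is about a number 1 percentage points higher from compound 1 to compound 4 (within the scatter), not clearly beyond the scatter in either direction. Compound 4 is therefore estimated at 10%, within a range from -20% to 35%.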

Compound 4, a percentage reported as activity, at one concentration (the size of the read-out at that concentration, not a potency): -43%
Estimate against measurement, compound 4: 53 percentage points above; the whole stated range lies above it.
By their numbers in this assay, from the lowest: compounds 4 and 3 (each within the scatter of the next); then compounds 2 and 1 (each within the scatter of the next).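

Among these compounds, the first single change that can be read in this assay is large: a number 52 percentage points lower from compound 1 to compound 4 (beyond the scatter) on going from 4-acetylphenyl to 4-(dimethylamino)phenyl. Both groups have the same count of heavy atoms and of hydrogen-bond acceptors, so the outcome at this place on the ring depends on which group sits there, not on those counts alone. Nothing measured here gives a cause for the step. As far as these compounds go, whether a plain amino group or a morpholine ring at this place would give a similar number stays open. So does whether the same swap would act alike on the core of compound 2.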